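The source may report more compounds than this note shows. Statements on the series, on what has been measured and on what is new or still open speak of the compounds shown alone.

Compound 1, `O=C(NN1CCOCC1)c1c(O)c2cccnc2n(-c2ccccc2)c1=O`: in a functional assay on the whole organism for inhibition, with Rattus norvegicus as the target, read by paw edema, at a dose of 100 mg/kg by the oral route (a lower number here means less inhibition, a higher number more inhibition at the dose given (going by the name of the read-out)), compound 1 gives -8.5%.
Compound 2, `O=C(Nc1ccccc1)c1c(O)c2cccnc2n(-c2ccccc2)c1=O`: compound 2 gives 4.6%.
Compound 3, `Cc1ccc(NC(=O)c2c(O)c3cccnc3n(-c3ccccc3)c2=O)cc1`: compound 3 gives -3.5%.

All three numbers sit close to zero. Compound 3 lies between the other two on the numbers shown, within the scatter of both: against compound 1 the step is a number 5 percentage points higher from compound 1 to compound 3 (within the scatter), and against compound 2 it is a number 8.1 percentage points lower from compound 2 to compound 3 (within the scatter). Among the measured compounds shown here, the only step beyond the scatter is a number 13.1 percentage points higher from compound 1 to compound 2 (beyond the scatter), which swaps the whole group on the amide-type nitrogen rather than a substituent on the aromatic ring.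

Compound 4, `O=C(Nc1ccc([N+](=O)[O-])cc1)c1c(O)c2cccnc2n(-c2ccccc2)c1=O`, has not yet been measured. It differs from compound 3 at one point: nitro in place of methyl on an aromatic carbon. The step that bears most directly on this change is a number 8.1 percentage points lower from compound 2 to compound 3 (within the scatter), since it alters the same aromatic carbon and stayed within the scatter. For the measured compounds named here, no measured step places a nitro group anywhere on the shared core, so there is no direct guide to its effect. On that basis the expected step is a number 4.5 percentage points higher from compound 3 to compound 4 (within the scatter), that is, nothing beyond the scatter, in either direction. The estimate for compound 4 in this assay is 1%, with a range from -13% to 15%.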

Compound 4, a percentage reported as inhibition, in the whole organism at one dose (the size of the read-out at that dose, not a potency): -7.6%
Beside the measured number, compound 4's estimate is 8.6 percentage points above it; the range from low to high includes it.
By their numbers in this assay, from the lowest: compounds 1, 4, 3 and 2 (each within the scatter of the next, the first and the last beyond it).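

In this assay, putting nitro in place of methyl on an aromatic carbon para to a large group gives a number 4.1 percentage points lower from compound 3 to compound 4 (within the scatter), and replacing morpholin-4-yl on the amide-type nitrogen with 4-nitrophenyl gives a number 0.9 percentage points higher from compound 1 to compound 4 (within the scatter), so neither change separates the compounds it links. Among the compounds shown here, the comparison with hydrogen on that same carbon reads differently: nitro in place of hydrogen gives a number 12.2 percentage points lower from compound 2 to compound 4 (beyond the scatter), a modest step beyond the scatter, whereas the earlier methyl in place of hydrogen gave a number 8.1 percentage points lower from compound 2 to compound 3 (within the scatter), so this is the first change at this carbon to exceed the scatter. No information at hand accounts for any of these steps.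

All four compounds remain close to zero at the one dose tested, so these compounds do not show whether any group on this aromatic carbon can bring a clear inhibition of paw edema. An amine, a carboxylic acid or a longer chain at this carbon remains an open case, as does the effect of any change to the shared core itself.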